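Three Inactive Amides and a Fourth Still Untested

This account rests on a few compounds, and the source may have more. Where it says the series, first, only, none or still open, it means among the compounds named here.

Three compounds share one core: compound 1 `C=CC1=C(C(=O)NCc2ccc(C)cc2)C(c2ccc(F)cc2)OC1`, compound 2 `C=CC1=C(C(=O)Nc2ccccc2)C(c2ccc(Cl)c(Cl)c2)OC1` and compound 3 `C=CC1=C(C(=O)Nc2ccc(OCC)cc2)C(c2ccc(OC)cc2)OC1`, each carrying an amide whose nitrogen bears a different aromatic group. In a functional assay on HeLa cells (Homo sapiens) for cytotoxicity, read by MTT assay, with a stated time of 24 h (a lower number here means a stronger inhibitor, a higher number a weaker inhibitor), compound 1 gives > 100000 nM, which is a limit of the assay and not a number. Compound 2 reaches only > 100000 nM, again a limit. Compound 3 stands at > 100000 nM, also a limit. Compound 3 therefore sits exactly where the other two sit, at the limit of > 100000 nM in this assay, at which 3 of the 3 values shown sit, and no ordering among the three can be drawn from this. Every value is a limit. Within the data shown here, no measured step between any pair can be computed.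

Compound 4, `C=CC1=C(C(=O)NCc2ccc(Cl)cc2)C(c2ccc(OC)cc2)OC1`, differs from compound 3 by 4-chlorobenzyl in place of 4-ethoxyphenyl on an amide-type nitrogen. The three measured compounds give no sign that any group on this nitrogen moves the number away from the limit, so the expected change from compound 3 is none beyond the scatter, namely a number no higher from compound 3 to compound 4 (the limit leaves the size open). Compound 4 is thus expected to come out at 100000 nM, within a range from 30000 nM to 300000 nM, most likely reported again as a limit.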

Compound 4, half-maximal inhibitory concentration: > 100000 nM
Compound 4 ended at the assay's limit (the forecaster's own chance of this, stated with the estimate: 80%); the middle value sits exactly at the limit.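

No step from compound 3 to compound 4 can be read, since neither value is a number, only a limit of the assay: the limit of > 100000 nM in this assay, at which 4 of the 4 values shown sit.

The compounds shown leave open whether any group on the amide-type nitrogen can give a readable value in this assay.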